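The compounds below may be only part of what the source reports. "The series", "measured", "known", "first", "only" and "open" are said of these compounds alone.

Measured in a functional assay on MCF7 cells (Homo sapiens) for antiproliferative activity, read by MTT assay, with a stated time of 48 h; on this read-out higher numbers stand for weaker inhibition and lower numbers for stronger inhibition:
- compound 1 `CC(=O)Oc1c(Br)cc(Br)cc1/C=C1\N=C(c2ccccc2)N(C(N)=S)NC1=O`: 28500 nM
- compound 2 `COc1ccc(C2=N/C(=C\c3cc(Br)cc(Br)c3OC(C)=O)C(=O)NN2C(N)=S)cc1OC`: 13400 nM
- compound 3 `COc1ccc(C2=N/C(=C\c3cc(Br)cc(Br)c3OC(C)=O)C(=O)n3c(C)nc(=S)n32)cc1OC`: 6840 nM

Within the data shown here, of these three numbers, the one for compound 1 is the highest, so it is the weakest inhibitor of the set in this assay. The next compound to be tested is compound 4 `CC(=O)Oc1c(Br)cc(Br)cc1/C=C1\N=C(c2ccccc2)N(c2ccccc2)NC1=O`, which differs from compound 1 in one place: a group of 6 heavy atoms (6 carbon; one six-membered aromatic ring of carbon only) in place of a group of 3 heavy atoms (1 carbon, 1 nitrogen, 1 sulfur; no ring), on an amine nitrogen in a ring.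

Among the measured compounds shown here, no measured step between compounds differing in one place touches that nitrogen. For the measured compounds named here, the only such step is a 2.1-fold lower number from compound 1 to compound 2 (0.33 log units; beyond the scatter), a modest change made elsewhere, on a carbon with a double bond to nitrogen. It shows how far a single added substitution has moved this series, but it says nothing about the direction of the present change. A step of similar modest size is therefore the best guide, and no change beyond the scatter is firmly expected, though the uncertainty is wide. The expected step is a 1.8-fold lower number from compound 1 to compound 4 (0.25 log units; within the scatter). For compound 4 the estimated value is 16000 nM, with an expected range from 5000 nM to 50000 nM.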

Compound 4, half-maximal inhibitory concentration: 19400 nM
The estimate for compound 4 lay 1.2-fold (0.08 log units) below the measured number; low and high end bracket the measured number.
By their numbers in this assay, from the lowest: compounds 3, 2, 4 and 1 (each within the scatter of the next, the first and the last beyond it).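

In this assay, the amine nitrogen in the ring now has a step of its own: phenyl in place of the group of 3 heavy atoms gives a 1.5-fold lower number from compound 1 to compound 4 (0.17 log units; within the scatter). On this nitrogen, with the rest of compound 1 unchanged, the two groups therefore cannot be told apart on this read-out, although only the group that leaves carries a hydrogen-bond donor and a hydrogen-bond acceptor, and only the group that enters holds a ring. Nothing available here offers an explanation for this result.

From the compounds shown here alone, whether a methyl or a benzyl group on this nitrogen would give a step beyond the scatter remains open. Also open, going by these compounds, is whether phenyl at this nitrogen would read the same alongside the 3,4-dimethoxyphenyl group of compound 2.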